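Trifluoromethyl for Methyl on the Aryl Ring

This account rests on a few compounds, and the source may have more. Where it says the series, first, only, none or still open, it means among the compounds named here.

Measured in a functional assay on U-87MG ATCC cells (Homo sapiens) for inhibition, read by MTT assay, with a stated time of 72 h; a higher number here means a weaker inhibitor, a lower number a stronger inhibitor:
- compound 1 `COc1cc2c(Oc3ccc(NC(=O)c4nn(-c5ccccc5C)c(=O)cc4C)cc3F)ccnc2cc1OCCCN1CCCC1`: 2960 nM
- compound 2 `COc1cc2c(Oc3ccc(NC(=O)c4nn(-c5ccccc5C)c(=O)cc4C)cc3F)ccnc2cc1OCCCN1CCCCC1`: 2500 nM
- compound 3 `COc1cc2c(Oc3ccc(NC(=O)c4nn(-c5ccccc5C)c(=O)cc4C)cc3F)ccnc2cc1OCCCN1CCC(C)CC1`: 2240 nM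

Compound 2 stands between the other two in this assay, and all three sit within the scatter of one another: a 1.2-fold lower number from compound 1 to compound 2 (0.07 log units; within the scatter), a 1.1-fold lower number from compound 2 to compound 3 (0.05 log units; within the scatter) and a 1.3-fold lower number from compound 1 to compound 3 (0.12 log units; within the scatter). Compound 4 `COc1cc2c(Oc3ccc(NC(=O)c4nn(-c5ccccc5C(F)(F)F)c(=O)cc4C)cc3F)ccnc2cc1OCCCN1CCCCC1` differs from compound 2 by trifluoromethyl in place of methyl on an aromatic carbon. Going by the values given here, none of the measured steps touches this part of the molecule; each of them concerns only the amine at the end of the chain, so no measured step bears directly on the change. With nothing in the data pointing either way, compound 4 is expected to show no step beyond the scatter, no change at the digits printed from compound 2 to compound 4 (within the scatter). Compound 4 is therefore estimated at 2500 nM in this assay, within a range of 800 nM to 8000 nM.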

Compound 4, half-maximal inhibitory concentration: 1150 nM
Beside the measured number, compound 4's estimate is 2.2-fold (0.34 log units) above it; the range from low to high includes it.
By their numbers in this assay, from the lowest: compounds 4, 3, 2 and 1 (each within the scatter of the next, the first and the last beyond it).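

Of the changes shown, this is the first to move the number beyond the scatter: in this assay, trifluoromethyl in place of methyl on the aromatic carbon gives a 2.2-fold lower number from compound 2 to compound 4 (0.34 log units; beyond the scatter), a modest step, whereas every step among the amines at the end of the chain stayed within the scatter. No evidence is available on what lies behind this step. The compounds shown leave open how chloro, methoxy or hydrogen would read at this place. They also leave open whether the step would hold with pyrrolidin-1-yl or 4-methylpiperidin-1-yl on the chain.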